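Methoxy to Trifluoromethyl, Tried Again on a Chloro Analogue

The source may hold more compounds than are shown below. What is called first, only, known or untested is meant among the compounds shown, and "the series" means these compounds.

Measured so far:
Compound 1, `COc1ccc(C2=NN(c3nc(-c4ccc(OC)cc4)cs3)C(c3cccs3)C2)cc1`: 16200 nM in a functional assay on MCF7 cells (Homo sapiens) for antiproliferative activity, read by MTT assay, with a stated time of 48 h; a lower number here means a stronger inhibitor, a higher number a weaker inhibitor
Compound 2, `COc1ccc(C2=NN(c3nc(-c4ccc(C(F)(F)F)cc4)cs3)C(c3cccs3)C2)cc1`: 45700 nM in this assay
Compound 3, `COc1ccc(-c2csc(N3N=C(c4ccc(Cl)cc4)CC3c3cccs3)n2)cc1`: 2480 nM in this assay

The three measured compounds share one core and differ only in a single group on a benzene ring. Compound 3 differs from compound 1 by chloro in place of methoxy on an aromatic carbon, and this change gave a 6.5-fold lower number from compound 1 to compound 3 (0.82 log units; beyond the scatter), making compound 3 the most potent of the three. Compound 2 differs from compound 1 by trifluoromethyl in place of methoxy on an aromatic carbon, and that change went the other way, with a 2.8-fold higher number from compound 1 to compound 2 (0.45 log units; beyond the scatter).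

Compound 4, `FC(F)(F)c1ccc(-c2csc(N3N=C(c4ccc(Cl)cc4)CC3c3cccs3)n2)cc1`, has not yet been measured. Among the compounds with values here, it differs from compound 3 by trifluoromethyl in place of methoxy on an aromatic carbon, which is the same change, at the same place, as the one from compound 1 to compound 2. If that change behaves alike on the chloro core, compound 4 is expected to lose some potency relative to compound 3, an expected step of a 2.8-fold higher number from compound 3 to compound 4 (0.45 log units; beyond the scatter), because of a 2.8-fold higher number from compound 1 to compound 2 (0.45 log units; beyond the scatter). For compound 4 the estimate in this assay is therefore 7000 nM, expected to fall between 2500 nM and 20000 nM.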

Compound 4, half-maximal inhibitory concentration: 160 nM
Compound 4: middle estimate off by 44-fold (1.64 log units), on the high side; measured number below the stated range.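

Trifluoromethyl in place of methoxy does not carry over from one core to the other in this series: on the core of compound 3 it gives a 16-fold lower number from compound 3 to compound 4 (1.19 log units; beyond the scatter) in this assay, the opposite direction to the earlier step on the core of compound 1: the same change on two cores in this assay, a 2.8-fold higher number (0.45 log units; beyond the scatter) from compound 1 to compound 2 and a 16-fold lower number (1.19 log units; beyond the scatter) from compound 3 to compound 4, 44-fold (1.64 log units) apart, beyond the scatter of two such steps

Chloro in place of methoxy keeps its direction but not its size, with a 290-fold lower number from compound 2 to compound 4 (2.46 log units; beyond the scatter): the same change on two cores in this assay, a 6.5-fold lower number (0.82 log units; beyond the scatter) from compound 1 to compound 3 and a 290-fold lower number (2.46 log units; beyond the scatter) from compound 2 to compound 4, 44-fold (1.64 log units) apart, beyond the scatter of two such steps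

Within the data shown here, the effect of a change at one of these two places therefore depends on which group sits at the other, but four compounds show this for only one pair of groups and do not explain why it happens.

On these data alone, it remains open whether the same dependence would appear with bromo or methyl in place of chloro, or with an amine or a carboxylic acid in place of trifluoromethyl. As far as these compounds go, it is also open whether the pattern would hold in cell lines other than the one used here.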